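Chloro placed on the core of compound 1

This account rests on a few compounds, and the source may have more. Where it says the series, first, only, none or still open, it means among the compounds named here.

compound 1 `C#CCn1cc(C(=O)NC(CC(=O)Nc2ccccc2)c2ccccc2)c(=O)c2cccnc21` — > 10000 nM
compound 2 `C#CCn1cc(C(=O)NC(CC(=O)NC2CCCC2)c2ccccc2)c(=O)c2cc(F)c(Cl)nc21` — 4400 nM
compound 3 `C#CCn1cc(C(=O)NC(CC(=O)Nc2ccccn2)c2ccccc2)c(=O)c2cc(F)c(Cl)nc21` — > 10000 nM

In a functional assay on MIA PaCa-2 cells (Homo sapiens) for cytotoxicity, read by MTT assay, with a stated time of 72 h (a lower number here means a stronger inhibitor, a higher number a weaker inhibitor), compound 1 gives > 10000 nM, which is a limit of the assay and not a number. Two of the three values shown sit at the limit of > 10000 nM in this assay, at which 2 of the 3 values shown sit. Compound 2 gives 4400 nM in this assay. Compound 3 gives > 10000 nM, again a limit. Among the compounds with values here, the only step that differs in one place, an at least 2.2-fold higher number from compound 2 to compound 3 (0.35 log units; beyond the scatter), concerns the amide nitrogen, not the core. Compound 4 `C#CCn1cc(C(=O)NC(CC(=O)Nc2ccccc2)c2ccccc2)c(=O)c2ccc(Cl)nc21` differs from compound 1 by chloro in place of hydrogen on an aromatic carbon. Within the data shown here, no measured step isolates this change, so no direction beyond the scatter is expected, and the expected step is an at least 1.1-fold lower number from compound 1 to compound 4 (0.04 log units; that floor lies within the scatter), which against a limit can only be read loosely. Compound 4 is estimated at 9000 nM, between 3000 nM and 30000 nM.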

Compound 4, half-maximal inhibitory concentration: 3000 nM
Beside the measured number, compound 4's estimate is 3.0-fold (0.48 log units) above it, and the stated range covers the measured number.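

Chloro in place of hydrogen on an aromatic carbon, next to the ring nitrogen, gives an at least 3.3-fold lower number from compound 1 to compound 4 (0.52 log units; beyond the scatter) in this assay. This is the first step shown on the shared core, as the earlier step concerned only the amide nitrogen, and it shows that this position responds to a single heavy atom. Compound 1 stands at a limit of the assay, so the step gives only a floor on the size of the change: the limit of > 10000 nM in this assay, at which 2 of the 4 values shown sit.

Going by these compounds, whether this response is specific to chloro stays open. Bromo, methoxy or an amine on the same carbon would test that.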